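The source may report more compounds than this note shows. Statements on the series, on what has been measured and on what is new or still open speak of the compounds shown alone.

Working notes on the series. In a functional assay on SW1573 cells (Homo sapiens) for inhibition, read by sulforhodamine B assay, with a stated time of 48 h (a lower number here means a stronger inhibitor of growth, a higher number a weaker inhibitor of growth), compound 1 `COC(=O)[C@@]1(C)CCC=C2[C@@H]1CC[C@@H](C)[C@]2(C)Cc1c[nH]c2c(C)cccc12` gives 7800 nM. In this assay compound 2 `COC(=O)[C@@]1(C)CCC=C2[C@@H]1CC[C@@H](C)[C@]2(C)Cc1c(C)[nH]c2ccc(F)cc12` gives 12000 nM. In this assay compound 3 `COC(=O)[C@@]1(C)CCC=C2[C@@H]1CC[C@@H](C)[C@]2(C)Cc1c(C)[nH]c2c(C)cccc12` gives 15000 nM, the highest number of the three shown, although the gaps to compound 2 (nearest) and to compound 1 (furthest) both lie within the scatter. Among the measured compounds shown here, the single step between measured compounds differing in one place, a 1.9-fold higher number from compound 1 to compound 3 (0.28 log units; within the scatter), is a methyl in place of hydrogen on an aromatic carbon and stays within the scatter.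

Compound 4 `COC(=O)[C@@]1(C)CCC=C2[C@@H]1CC[C@@H](C)[C@]2(C)Cc1c(C)[nH]c2c(Cl)cccc12` differs from compound 3 by chloro in place of methyl on an aromatic carbon. For the measured compounds named here, no measured pair exchanges methyl for chloro, so nothing in the data speaks to this change directly; the only measured change at an aromatic carbon, a 1.9-fold higher number from compound 1 to compound 3 (0.28 log units; within the scatter), stayed within the scatter. For compound 4 the expected step is therefore a 1.3-fold lower number from compound 3 to compound 4 (0.10 log units; within the scatter), nothing beyond the scatter in either direction. Compound 4 is estimated at 12000 nM, with a range of 5000 nM to 30000 nM.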

Compound 4, concentration for 50% growth inhibition: 19000 nM
The estimate for compound 4 lay 1.6-fold (0.20 log units) below the measured number, within the range that was stated.
By their numbers in this assay, from the lowest: compounds 1, 2, 3 and 4 (each within the scatter of the next, the first and the last beyond it).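

In this assay, the exchange on this aromatic carbon of the six-membered aromatic ring, ortho to a fused ring and meta to a fused ring, gives a 1.3-fold higher number from compound 3 to compound 4 (0.10 log units; within the scatter), so chloro and methyl are not separated here. Among the compounds shown here, this is the first step read at this carbon, since the earlier step between measured compounds concerned a different aromatic carbon, and at this carbon the number stays within the scatter when a carbon is replaced by a chlorine. No measurement on these compounds accounts for this result.

From the compounds shown here alone, whether a group unlike these two, such as an amine, a carboxylic acid or a methoxy, would move the number beyond the scatter at this carbon stays open. Also open, going by these compounds, is what hydrogen at this carbon would give with the rest of compound 3 kept.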